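Aryl sulfonyl swap carried from one linker to the other

This account rests on a few compounds, and the source may have more. Where it says the series, first, only, none or still open, it means among the compounds named here.

Values in a functional assay on HL-60 cells (Homo sapiens) for cytotoxicity, read by luminescence; a lower number here means a stronger inhibitor, a higher number a weaker inhibitor:

compound 1 `C=C(CC)C(=O)c1ccc(OCC(=O)N2CCN(S(=O)(=O)c3cc(Cl)ccc3OC)CC2)c(Cl)c1Cl`: 1410 nM
compound 2 `C=C(CC)C(=O)c1ccc(OCC(=O)N2CCN(S(=O)(=O)c3ccc([N+](=O)[O-])cc3)CC2)c(Cl)c1Cl`: 3260 nM
compound 3 `C=C(CC)C(=O)c1ccc(OCC(=O)NC2CCN(S(=O)(=O)c3cc(Cl)ccc3OC)CC2)c(Cl)c1Cl`: 700 nM

Compound 1 and compound 3 share the same ketone-bearing aryl ether and the same sulfonyl aryl group; the difference between their two cores is not broken down here. Of the three numbers, compound 3 has the lowest, but its gap to compound 1 is within the scatter, so no order between those two is claimed. Compound 2 stands beyond the scatter from compound 3.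

Within the core of compound 1, the change 4-nitrophenyl in place of 5-chloro-2-methoxyphenyl on a sulfonyl sulfur gave a 2.3-fold higher number from compound 1 to compound 2 (0.36 log units; beyond the scatter) in this assay.

Compound 4 `C=C(CC)C(=O)c1ccc(OCC(=O)NC2CCN(S(=O)(=O)c3ccc([N+](=O)[O-])cc3)CC2)c(Cl)c1Cl` is the same change made on the core of compound 3: 4-nitrophenyl in place of 5-chloro-2-methoxyphenyl on a sulfonyl sulfur. The place around the change reads the same in both pairs, so it is taken as the same change. Within the data shown here, a step of about the same size is expected, a 2.3-fold higher number from compound 3 to compound 4 (0.36 log units; beyond the scatter), resting on the one measured precedent, a 2.3-fold higher number from compound 1 to compound 2 (0.36 log units; beyond the scatter). Compound 4 is therefore estimated at 1600 nM in this assay, with the range 700 nM to 3600 nM allowing for a single precedent and the usual scatter.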

Compound 4, half-maximal inhibitory concentration: 2470 nM
For compound 4 the middle estimate is 1.5-fold (0.19 log units) below the measured one; the range from low to high includes it.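

In this assay, 4-nitrophenyl in place of 5-chloro-2-methoxyphenyl on the sulfonyl sulfur gave a 3.5-fold higher number from compound 3 to compound 4 (0.55 log units; beyond the scatter), so the change goes in the same direction on the second core as on the first. The two steps do not differ in size beyond what repeated measurement would allow, and in this series the change can be carried between these two cores as one step: the same change on two cores in this assay, a 2.3-fold higher number (0.36 log units; beyond the scatter) from compound 1 to compound 2 and a 3.5-fold higher number (0.55 log units; beyond the scatter) from compound 3 to compound 4, 1.5-fold (0.18 log units) apart, within the scatter of two such steps. Among these compounds, this rests on a single aryl swap on only two cores, so it does not show that the step would hold on any other core or for any other group on the sulfonyl sulfur, and it gives no reason for the step.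

Still open, on these data alone, is how a plain phenyl or a methyl on the sulfonyl sulfur would read in this assay, or an aryl group carrying an amine or a carboxylic acid. Also open, as far as these compounds go, is whether the chlorine or the methoxy of the 5-chloro-2-methoxyphenyl group alone would give the same step.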